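Swapping the bromo group for tert-butyl on the thioether aryl ring

The compounds below may be only part of what the source reports. "The series", "measured", "known", "first", "only" and "open" are said of these compounds alone.

Measured compounds:
compound 1, `Nc1ccccc1NC(=O)c1ccc(CSc2ccc(Br)cc2)cc1`, 67.7%
compound 2, `Nc1ccccc1NC(=O)c1ccc(CSc2cccc(F)c2)cc1`, 81.4%

Of the compounds shown here, two have been tested in a functional assay on HCT-116 cells (Homo sapiens) for inhibition, read by CCK-8 assay, with a stated time of 72 h, tested at 8 uM; a lower number here means less inhibition of growth, a higher number more inhibition of growth at the concentration tested. Compound 1 gives 67.7%, the lowest of the two numbers, while compound 2 gives 81.4%. Within the data shown here, the single step between them, a number 13.7 percentage points higher from compound 1 to compound 2 (beyond the scatter), changes the aryl group on the sulfur and lies beyond the scatter.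

Compound 3, `CC(C)(C)c1ccc(SCc2ccc(C(=O)Nc3ccccc3N)cc2)cc1`, has not yet been measured. It differs from compound 1 as follows:

tert-butyl in place of bromo on an aromatic carbon

Among the measured compounds shown here, the one measured step exchanges the whole aryl ring on the sulfur, whereas the change to compound 3 keeps the ring and replaces only the substituent on it, "para to a large group". For the measured compounds named here, no measured step therefore bears directly on a bromo-to-tert-butyl exchange, and the expectation for compound 3 rests on the value of compound 1 alone. Compound 3 is expected to stay close to compound 1, with a step of a number 2.7 percentage points lower from compound 1 to compound 3 (within the scatter) that need not exceed the scatter. The estimate for compound 3 is 65%, within a range of 45% to 85%.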

Compound 3, percent growth inhibition at one concentration: 60.5%
The estimate for compound 3 lay 4.5 percentage points above the measured number; measured number inside the range.
By their numbers in this assay, from the lowest: compounds 3 and 1 (each within the scatter of the next); then compound 2.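

The exchange of bromo for tert-butyl on the aromatic carbon para to a large group gives in this assay a result of a number 7.2 percentage points lower from compound 1 to compound 3 (within the scatter) and so leaves compound 3 and compound 1 indistinguishable in this read-out. Unlike the earlier step, which replaced the whole aryl group on the sulfur, this one keeps the ring and alters only its substituent, showing that this place accepts tert-butyl, with 4 heavy atoms, as well as bromo, with 1 heavy atom, without a difference beyond the scatter. Nothing available offers an explanation for this outcome, and no measurement bears on why the two groups read alike.

The compounds shown leave open whether a group of a different kind at this same place, such as an amine or a carboxylic acid, would also stay within the scatter of compound 1 or would move the number clearly. They also leave open whether a fluoro group at this place would match the higher number of compound 2, since that compound differs from compound 1 in both the substituent and its place on the ring.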